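A few compounds are considered here, and "the series" means these few. Any claim that something is new, unique, unknown or untested is made for them only; others in the source may bear on it.

Measured so far:
- Compound 1 `O=C1c2c[n+]([O-])c3ccccc3c2C(=O)c2c1c1ccccc1n2CCCCn1ccnc1`: 240 nM
- Compound 2 `O=C1c2c[n+]([O-])c3ccccc3c2C(=O)c2c1c1ccccc1n2CCN1CCCC1`: 270 nM

Going by the values given here, in a functional assay on HCT-116 cells (Homo sapiens) for cytotoxicity, read by MTT assay, with a stated time of 72 h (a higher number here means a weaker inhibitor, a lower number a stronger inhibitor), compound 2 stands level with the only other measured compound, with a 1.1-fold higher number from compound 1 to compound 2 (0.05 log units; within the scatter). Compound 3 `CCCCN1CCN(CCCCn2c3c(c4ccccc42)C(=O)c2c[n+]([O-])c4ccccc4c2C3=O)CC1` is the next to read, with this change: 2-(4-butylpiperazin-1-yl)ethyl in place of pyrrolidin-1-yl on a saturated chain carbon, two bonds along the chain from an aromatic nitrogen. This places 2-(4-butylpiperazin-1-yl)ethyl in place of pyrrolidin-1-yl on a saturated chain carbon, two bonds along the chain from an aromatic nitrogen. Among the compounds with values here, the one measured step bearing on this, a 1.1-fold higher number from compound 1 to compound 2 (0.05 log units; within the scatter), stayed within the scatter, so no shift beyond the scatter is expected in this assay. The expected change is a 1.1-fold lower number from compound 2 to compound 3 (0.03 log units; within the scatter). One step is thin support, so the range is kept wide. For compound 3 the estimated value is 250 nM, with an expected range of 100 nM to 650 nM.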

Compound 3, half-maximal inhibitory concentration: 1920 nM
The estimate for compound 3 lay 7.7-fold (0.89 log units) below the measured number; the measured number lies above the stated range.
By their numbers in this assay, from the lowest: compounds 1 and 2 (each within the scatter of the next); then compound 3.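

In this assay, the chain end is not indifferent to the group it carries: 2-(4-butylpiperazin-1-yl)ethyl in place of pyrrolidin-1-yl gives a 7.1-fold higher number from compound 2 to compound 3 (0.85 log units; beyond the scatter), and 4-butylpiperazin-1-yl in place of 1H-imidazol-1-yl gives an 8.0-fold higher number from compound 1 to compound 3 (0.90 log units; beyond the scatter). Both steps lie beyond the scatter, so the two smaller groups' agreement does not extend to this larger one. Nothing measured here accounts for the rise.

On these data alone, whether the butyl group or the piperazine ring carries the loss stays open. A piperazin-1-yl or 4-methylpiperazin-1-yl group at this place would separate the two.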